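Swapping one ring on a short-lived compound

The source may report more compounds than this note shows. Statements on the series, on what has been measured and on what is new or still open speak of the compounds shown alone.

Values so far in an ADME assay on microsomes from liver (Mus musculus, strain CD-1) for metabolic stability, read by LC-MS, with a stated time of 60 min, tested at 20 uM; on this read-out lower numbers stand for a shorter-lived compound and higher numbers for a longer-lived compound

Compound 1 `Cn1ncc2c(=O)n(-c3ccccc3)c(SCc3cccc(F)c3)cc21` gives 0.15 h
Compound 2 `C[C@@H](Sc1nc2c(cnn2C)c(=O)n1-c1ccccc1)c1ccccc1` gives 0.133 h
Compound 3 `O=c1c2cn(C3COC3)nc2nc(SCc2cccc(F)c2)n1-c1ccccc1` gives 0.383 h

Compound 2 at 0.133 h sits at the low end of these numbers, within the usual scatter of compound 1 at 0.15 h and clearly lower than compound 3, which gives 0.383 h on this half-life scale. Compound 4 `CC(Sc1nc2c(cnn2C)c(=O)n1-c1ccccc1)c1cncnc1` has not been measured yet. It differs from compound 2 by 1-(pyrimidin-5-yl)ethyl in place of 1-phenylethyl on a sulfur and so carries 1-(pyrimidin-5-yl)ethyl in place of 1-phenylethyl on a sulfur.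

Within the data shown here, no two measured compounds differ in just one place, so nothing here shows directly what such a swap does. The only hint is that compound 3 reaches 0.383 h and so shows that a longer half-life is possible among these structures. The expected change is a 2.3-fold higher number from compound 2 to compound 4 (0.35 log units; beyond the scatter) in this assay and would be a modest step toward a longer-lived compound, just beyond the scatter. The estimate for compound 4 is 0.3 h with an expected range of 0.13 h to 0.7 h on this read-out.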

Compound 4, half-life: 0.133 h
The estimate for compound 4 lay 2.3-fold (0.35 log units) above the measured number; the measured number falls inside the stated range.
By their numbers in this assay, from the lowest: compounds 2, 4 and 1 (each within the scatter of the next); then compound 3.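

In this assay, putting 1-(pyrimidin-5-yl)ethyl in place of 1-phenylethyl on a sulfur gives no change at the digits printed from compound 2 to compound 4 (within the scatter). Among these compounds, this is the first direct reading of a single change in this set: a six-membered aromatic ring of carbon only gives way to one with 2 hetero atoms, and the half-life stays within the scatter, so this swap gives no gain in lifetime on this read-out. No measurement shown explains this outcome.

Still open, on these data alone, is whether a different kind of group on this sulfur, such as an amine, a carboxylic acid or a longer chain, would change the half-life. It is also unknown whether the same swap would leave the number unchanged on compound 1 or compound 3, which have other structures elsewhere.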